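From cyclopropyl to 4-fluorophenyl on an amide-type nitrogen

The compounds below may be only part of what the source reports. "The series", "measured", "known", "first", "only" and "open" are said of these compounds alone.

Compound 2 (`O=C1COc2ccc(-c3cccc(NS(=O)(=O)c4ccc(F)cc4)c3)cc2N1C1CC1`) gives > 40000 nM in a functional assay on MCF7 cells (Homo sapiens) for antiproliferative activity, read by MTT assay, with a stated time of 72 h (on this read-out higher numbers stand for weaker inhibition and lower numbers for stronger inhibition), and this is a limit, not a number. Compound 3 (`O=C1COc2ccc(-c3cccc(NS(=O)(=O)c4ccc(F)cc4)c3)cc2N1c1ccc(F)cc1`) carries 4-fluorophenyl in place of cyclopropyl on an amide-type nitrogen in a ring. The closest measured relative is compound 1 (`O=C1COc2ccc(-c3cccc(NS(=O)(=O)c4ccc(F)cc4)c3)cc2N1c1ccc(Cl)cc1`), which holds 4-chlorophenyl at that nitrogen and gives 39800 nM in this assay as a true number. Among the compounds with values here, only one measured step bears on the change, namely a number no lower from compound 1 to compound 2 (the limit leaves the size open) when cyclopropyl replaces 4-chlorophenyl, and its size cannot be read. With compound 1 at 39800 nM as the guide, only a small gain in inhibition is expected. The expected change an at least 1.3-fold lower number from compound 2 to compound 3 (0.12 log units; that floor lies within the scatter) is therefore modest, and a second limit result would be no surprise. For compound 3 the estimate is 30000 nM (expected range 15000 nM to 40000 nM).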

Compound 3, half-maximal inhibitory concentration: > 40000 nM
Compound 3 was reported as a limit; the forecaster's own chance of this, stated with the estimate: 40%; at least 1.3-fold (0.12 log units) between middle value and limit.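

In this assay, compound 3 gives > 40000 nM, which is a limit of the assay and not a number. Fluoro in place of chloro on an aromatic carbon gives a number no lower from compound 1 to compound 3 (the limit leaves the size open). A 4-fluorophenyl on this amide-type nitrogen therefore does not yield a readable number, so having a phenyl ring at this position is not enough on its own, and compound 1, with 4-chlorophenyl, remains the only one of the three with a true number, 39800 nM. The steps to compound 3 cannot be read, because the values stop at one ceiling: the limit of > 40000 nM in this assay, at which 2 of the 3 values shown sit.

On these data alone, how far compound 2 and compound 3 lie past that limit remains open, and so does whether fluoro and chloro on the phenyl ring truly differ. Also open, as far as these compounds go, is whether a group of another kind on this nitrogen, such as an aminoethyl chain or a chain ending in a carboxylic acid, would give a clearly lower number.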